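This account rests on a few compounds, and the source may have more. Where it says the series, first, only, none or still open, it means among the compounds named here.

For the measured compounds named here, compound 3 `CCn1c(C(=O)N[C@H](CO)CCO)ccc1C(CC)(CC)c1ccc(OCS(=O)(=O)c2ccccc2)c(C)c1` gives 15900 nM in a functional assay on BXPC-3 cells (Homo sapiens) for antiproliferative activity, read by MTT assay, with a stated time of 24 h (a higher number here means a weaker inhibitor, a lower number a stronger inhibitor), the higher of the two numbers known here; compound 2 `CCn1c(C(=O)N[C@H](CO)C(C)C)ccc1C(CC)(CC)c1ccc(OCS(=O)(=O)c2ccccc2)c(C)c1` gives 7720 nM in this assay, and the two are separated by a 2.1-fold higher number from compound 2 to compound 3 (0.31 log units; beyond the scatter). Compound 1 `CCn1c(C(=O)N[C@@H](CC(=O)OC)C(=O)OC)ccc1C(CC)(CC)c1ccc(OCS(=O)(=O)c2ccccc2)c(C)c1` returns only the limit > 50000 nM in this assay. Compound 4 `CCn1c(C(=O)N[C@@H](CC(=O)O)C(=O)O)ccc1C(CC)(CC)c1ccc(OCS(=O)(=O)c2ccccc2)c(C)c1` carries 1,2-dicarboxyethyl in place of 3-hydroxy-1-(hydroxymethyl)propyl on an amide-type nitrogen. Of the measured steps, an at least 3.1-fold lower number from compound 1 to compound 3 (0.49 log units; beyond the scatter) bears on it; the 1,2-bis(methoxycarbonyl)ethyl group there is the ester form of the 1,2-dicarboxyethyl group that enters compound 4. A return toward that earlier pattern is expected, with the number rising, and the step expected is a 3.8-fold higher number from compound 3 to compound 4 (0.58 log units; beyond the scatter), quite possibly back to a limit. Compound 4 is estimated at 60000 nM, with a range from 20000 nM to 200000 nM.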

Compound 4, half-maximal inhibitory concentration: > 50000 nM
Compound 4 ended at the assay's limit; the forecaster's own chance of this, stated with the estimate: 60%; the middle value lies beyond the limit too.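

The free 1,2-dicarboxyethyl group does not restore a readable number in this assay: in place of 3-hydroxy-1-(hydroxymethyl)propyl it gives an at least 3.1-fold higher number from compound 3 to compound 4 (0.49 log units; beyond the scatter), and in place of 1-(hydroxymethyl)-2-methylpropyl it gives an at least 6.4-fold higher number from compound 2 to compound 4 (0.81 log units; beyond the scatter). Among the compounds shown, only those with a hydroxyl-bearing group on the amide-type nitrogen give a number, so both the diester and the diacid fall outside the measurable range. Compound 4, like compound 1, stands at a limit and not at a number, so the step between them cannot be read: the limit of > 50000 nM in this assay, at which 2 of the 4 values shown sit.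

Going by these compounds, whether a single carboxylic acid, a primary amide or an amine on this chain would return a readable number remains open. So does how far beyond the limit compound 4 lies.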